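Swapping the aryl amide for a branched alkyl chain

This account rests on a few compounds, and the source may have more. Where it says the series, first, only, none or still open, it means among the compounds named here.

Measured compounds and their values in a functional assay on WI-38 VA13 cells (Homo sapiens) for cytotoxicity; a higher number here means that more compound is needed for the effect, a lower number that less compound is needed:
- compound 1, `O=C(Nc1ccc2nc(NC(=O)C3CCCCC3)sc2c1)c1ccccc1C(F)(F)F`: 0.024 ug/mL
- compound 2, `O=C(Nc1ccc2nc(NC(=O)C3CCCCC3)sc2c1)c1ccc(Br)cc1`: a limit of the assay, > 4 ug/mL
- compound 3, `O=C(Nc1ccc2nc(NC(=O)C3CCCCC3)sc2c1)c1c(F)cccc1C(F)(F)F`: 0.032 ug/mL

Compound 1 holds the lowest of the two numbers; its nearest neighbour is compound 3, with a 1.3-fold higher number from compound 1 to compound 3 (0.12 log units; within the scatter). Compound 2 gave no number, only (the limit of > 4 ug/mL in this assay, at which 1 of the 3 values shown sits).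

Compound 4, `CCCC(C)C(=O)Nc1ccc2nc(NC(=O)C3CCCCC3)sc2c1`, is not yet measured. It differs from compound 1 in one place: 1-methylbutyl in place of 2-(trifluoromethyl)phenyl on a carbonyl carbon.

Within the data shown here, two measured steps bear on this. Exchanging the aromatic group for another aromatic group gave an at least 160-fold higher number from compound 1 to compound 2 (2.22 log units; beyond the scatter), so this assay reacts strongly to what sits on that carbonyl carbon. Adding a fluoro to the same ring gave a 1.3-fold higher number from compound 1 to compound 3 (0.12 log units; within the scatter). Replacing the whole ring with a short chain is a larger change than either, so a large rise in the number is expected for compound 4, in the direction of a 63-fold higher number from compound 1 to compound 4 (1.80 log units; beyond the scatter). The estimate for compound 4 in this assay is 1.5 ug/mL, with a range from 0.2 ug/mL to 6 ug/mL, and a real chance that only a limit is reported.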

Compound 4, half-maximal effective concentration: 0.14 ug/mL
For compound 4 the middle estimate is 11-fold (1.03 log units) above the measured one; measured number outside the range, below it.
By their numbers in this assay, from the lowest: compounds 1 and 3 (each within the scatter of the next); then compound 4. At a limit, above all of these: compound 2.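

In this assay, an aromatic ring on this carbonyl carbon turns out not to be needed for a low number: replacing 2-(trifluoromethyl)phenyl with 1-methylbutyl, which has no ring, gives a 5.8-fold higher number from compound 1 to compound 4 (0.77 log units; beyond the scatter). The same chain gives an at least 28-fold lower number from compound 2 to compound 4 (1.45 log units; beyond the scatter), so at this position a chain can give a lower number than one aromatic group and a higher number than another, and the presence of a ring alone does not decide the outcome. The comparison with compound 2 rests on a limit, not a number: the limit of > 4 ug/mL in this assay, at which 1 of the 4 values shown sits.

From the compounds shown here alone, whether the branch in 1-methylbutyl matters stays open, and a straight pentyl chain would test that. Going by these compounds, how a cyclohexyl group, or a chain carrying an amine or a carboxylic acid, would behave on this carbonyl carbon also remains open.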